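From 3-chlorophenyl to 4-fluorophenyl on the shared core

The source may report more compounds than this note shows. Statements on the series, on what has been measured and on what is new or still open speak of the compounds shown alone.

Measured so far in a functional assay on MV4-11 cells (Homo sapiens) for antiproliferative activity, read by CCK-8 assay, with a stated time of 72 h (on this read-out lower numbers stand for stronger inhibition and higher numbers for weaker inhibition), are
Compound 1 `Cn1cc(-c2ccccc2)c2cc(C(=O)NCc3ccc(C(=O)Nc4ccccc4N)cc3)[nH]c2c1=O` with 230 nM
Compound 2 `Cn1cc(-c2cccc(Cl)c2)c2cc(C(=O)NCc3ccc(C(=O)Nc4ccccc4N)cc3)[nH]c2c1=O` with 190 nM

Compound 2 at 190 nM lies within the scatter of compound 1 at 230 nM on these two numbers. Compound 3 `Cn1cc(-c2ccc(F)cc2)c2cc(C(=O)NCc3ccc(C(=O)Nc4ccccc4N)cc3)[nH]c2c1=O` differs from compound 2 by 4-fluorophenyl in place of 3-chlorophenyl on an aromatic carbon and so carries 4-fluorophenyl in place of 3-chlorophenyl on an aromatic carbon. For the measured compounds named here, the one measured step that bears on this is a 1.2-fold lower number from compound 1 to compound 2 (0.08 log units; within the scatter) and it stays within the scatter. No step beyond the scatter is therefore expected in this assay in either direction. The estimated change is a 1.1-fold higher number from compound 2 to compound 3 (0.04 log units; within the scatter) and is expected to stay small. Compound 3 is expected at 210 nM with an estimated range from 100 nM to 450 nM in this read-out.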

Compound 3, half-maximal inhibitory concentration: 220 nM
Compound 3: middle estimate off by 1.0-fold (0.02 log units), on the low side, within the range that was stated.
By their numbers in this assay, from the lowest: compounds 2, 3 and 1 (each within the scatter of the next).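

In this assay the exchange of 3-chlorophenyl for 4-fluorophenyl gives a 1.2-fold higher number from compound 2 to compound 3 (0.06 log units; within the scatter) and the fluoro group in place of hydrogen gives a 1.0-fold lower number from compound 1 to compound 3 (0.02 log units; within the scatter) on the shared core. This position thus holds phenyl, 3-chlorophenyl and 4-fluorophenyl with no step beyond the scatter, so a second halogen and a second ring place for it join the earlier result. Nothing available accounts for this, and no supporting measurement bears on it. On these data alone, whether an amine or a carboxylic acid on this phenyl ring would give a step beyond the scatter stays open. So does the outcome of replacing the phenyl ring with a longer chain.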